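Moving the ring oxygen of a piperidine amide's oxane cap

A few compounds are considered here, and "the series" means these few. Any claim that something is new, unique, unknown or untested is made for them only; others in the source may bear on it.

Compound 1, `O=C(Nc1ccc(OC(F)(F)F)cc1)NC1CCN(C(=O)C2CCCOC2)CC1`, was examined in a physicochemical assay for solubility, read by mass spectrometry, in phosphate buffer, with a stated time of 24 h, at pH 7.4 (on this read-out lower numbers stand for lower solubility and higher numbers for higher solubility), where compound 1 gives 94 ug/mL. Among the three compounds measured in this assay, compound 1 holds the second highest number. The nearest of the others is compound 2, `CC[C@H](C)C(=O)N1CCC(NC(=O)Nc2ccc(C(F)(F)F)cn2)CC1`; in this assay compound 2 gives 274 ug/mL, a number higher than that of compound 1 by a margin beyond the usual scatter. The furthest is compound 3, `CC[C@H](C)C(=O)N1CCC(NC(=O)Nc2ccc(OC(F)(F)F)c(OC(F)(F)F)c2)CC1`; in this assay compound 3 gives 5.5 ug/mL, a number far lower than that of compound 1, again beyond the scatter. Neither of these pairs is a single-point step from compound 1, so they only frame where compound 1 sits.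

The step under consideration leads from compound 1 to compound 4, `O=C(Nc1ccc(OC(F)(F)F)cc1)NC1CCN(C(=O)C2CCOCC2)CC1`. The two have the same atoms, joined differently: oxan-4-yl in place of oxan-3-yl on a carbonyl carbon. The oxan-3-yl group leaves and an oxan-4-yl group enters on a carbonyl carbon whose other neighbour is an amide-type nitrogen in a ring.

Within the data shown here, no measured pair in this set isolates such a change, so there is nothing to set its size from directly. Given that the count of atoms, donors and acceptors is unchanged, the step from compound 1 to compound 4 in this assay is expected to be a 1.1-fold higher number from compound 1 to compound 4 (0.03 log units; within the scatter), that is, no shift beyond the scatter in either direction. Compound 4 is therefore estimated at 100 ug/mL, with a range from 45 ug/mL to 220 ug/mL.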

Compound 4, solubility: 91 ug/mL
The estimate for compound 4 lay 1.1-fold (0.04 log units) above the measured number; the range from low to high includes it.
By their numbers in this assay, from the lowest: compound 3; then compounds 4 and 1 (each within the scatter of the next); then compound 2.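

Among these compounds, compound 1 and compound 4 form the first pair in this set that differs in one place, and in this assay the exchange of oxan-3-yl for oxan-4-yl on the carbonyl carbon amounts to a 1.0-fold lower number from compound 1 to compound 4 (0.01 log units; within the scatter) on this read-out. The earlier compounds shown here differ from compound 1 in more than one place and could only frame its standing, whereas this pair isolates the acyl cap and shows that these two attachments of the same oxane ring cannot be told apart here. Nothing further is available to explain this result, so it stands as an observation about these two compounds alone.

This single pair leaves open whether the same exchange would stay within the scatter on a compound that differs at the other end of the molecule, such as one carrying the aryl group of compound 2 or compound 3. It also leaves open how far the number at this position would move if the oxane ring gave way to a group of a different kind, such as a piperidine amine, a carboxylic acid or a longer open ether chain.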